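A few compounds are considered here, and "the series" means these few. Any claim that something is new, unique, unknown or untested is made for them only; others in the source may bear on it.

Measured so far in a physicochemical assay for lipophilicity, using the shake flask method, at pH 7.4; on this read-out higher numbers stand for higher lipophilicity and lower numbers for lower lipophilicity:
- compound 1 `O=C(O)CCNC(=O)c1ccc(C(Oc2ccc(-n3cc(C(F)(F)F)cn3)cc2)C2CC2)cc1`: 1.7
- compound 2 `CC(C)(C)C(Oc1ccc(-n2cc(C(F)(F)F)cn2)cc1)c1ccc(C(=O)NCCC(=O)O)cc1`: 3.7

Compound 2, at 3.7, holds the higher of the two numbers in this assay. Compound 3 `CC(C)CC(Oc1ccc(-n2cc(C(F)(F)F)cn2)cc1)c1ccc(C(=O)NCCC(=O)O)cc1` has not yet been measured. Its structure departs from that of compound 2 as follows: isobutyl in place of tert-butyl on a saturated chain carbon bound to an aromatic carbon and an oxygen on an aromatic ring. In words, isobutyl stands in place of tert-butyl on a saturated chain carbon bound to an aromatic carbon and an oxygen on an aromatic ring. Among the measured compounds shown here, one measured step bears on this change, at the same place: a number 2.00 log units higher from compound 1 to compound 2 (beyond the scatter), which is large and beyond the scatter. For the measured compounds named here, no measured compound carries isobutyl, so that single step gives only a rough guide. A moderate fall, smaller than that step, is expected. The expected step is a number 0.70 log units lower from compound 2 to compound 3 (beyond the scatter). For compound 3 the estimated value is 3, with an expected range from 2.2 to 3.8.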

Compound 3, distribution coefficient: 3.2
Compound 3: middle estimate off by 0.20 log units, on the low side, and the stated range covers the measured number.
By their numbers in this assay, from the lowest: compound 1; then compound 3; then compound 2.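

Tert-butyl and isobutyl have the same atoms, joined differently, and in this assay this rearrangement on the saturated chain carbon still gives a number 0.50 log units lower from compound 2 to compound 3 (beyond the scatter) and so shows that the read-out at this place responds to how the carbons are joined, not only to which atoms are present. Isobutyl in place of cyclopropyl gives a number 1.50 log units higher from compound 1 to compound 3 (beyond the scatter) and thus keeps the larger part of the rise first seen with tert-butyl, with the isobutyl compound lying between the other two. Nothing measured on these compounds accounts for either step.

Three groups at one place cannot show whether the order among them would hold on a different core. Going by these compounds, how an unbranched butyl chain, a longer chain or an amine on this same carbon would read in this assay remains open.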